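Methyl on the ring nitrogen of compound 2

The compounds below may be only part of what the source reports. "The series", "measured", "known", "first", "only" and "open" are said of these compounds alone.

The series gathered so far sits at one low level in an assay on isolated protein for inhibition of MAP kinase-activated protein kinase 5 (Homo sapiens), read by mobility shift assay, tested at 30 uM; on this read-out higher numbers stand for more inhibition at the one concentration tested (going by the name of the read-out) and lower numbers for less inhibition. Compound 1 `COc1cccc(-c2cc3[nH]nc(N)c3c(=O)[nH]2)c1` gives 10% in this assay. Compound 2 `Cc1cc2[nH]nc(N)c2c(N2CCCCC2)n1` gives 10% in this assay, level with compound 1 at the digits reported, and together these two stand as the highest of the three numbers, although the gap down to compound 3 lies within the scatter. Compound 3 `Cc1cc2c(c(N)nn2C)c(=O)[nH]1` gives 5% in this assay, the lowest number of the three but within the scatter of both others. Nothing in these three numbers separates one compound from another.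

Compound 4 `Cc1cc2c(c(N)nn2C)c(N2CCCCC2)n1` has not yet been measured. It differs from compound 2 in one place: methyl in place of hydrogen on an aromatic nitrogen. Within the data shown here, no pair of measured compounds differing in a single place exists in this set, so the size of such a step cannot be read from the measured series. With every measured number lying at one low level, the step expected here is a number 2 percentage points lower from compound 2 to compound 4 (within the scatter), none beyond the scatter. Compound 4 is estimated at 8% in this assay, with a range from 0% to 20%.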

Compound 4, a percentage reported as inhibition, at one concentration (the size of the read-out at that concentration, not a potency): 17%
Beside the measured number, compound 4's estimate is 9 percentage points below it; measured number inside the range.
By their numbers in this assay, from the lowest: compounds 3, 1, 2 and 4 (each within the scatter of the next, the first and the last beyond it).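

Among these compounds, this is the first step that can be read between two compounds differing in one place: in this assay, methyl in place of hydrogen on an aromatic nitrogen of the five-membered aromatic ring gives a number 7 percentage points higher from compound 2 to compound 4 (within the scatter) and so does not separate the two compounds. The hydrogen on this nitrogen is therefore not required for the low inhibition seen with compound 2, and the position accepts a methyl without the number falling away, though the step lying within the scatter means no gain can be claimed either. No measurement at hand bears on the reason for this behaviour at the position.

From the compounds shown here alone, whether a larger group on this nitrogen, such as an ethyl, a longer chain or a chain ending in a carboxylic acid or an amine, would move the number beyond the scatter remains open. One methyl step, read at a single concentration and at a low level of inhibition, also leaves open whether the same change would hold up on a compound with a higher number.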